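The source may hold more compounds than are shown below. What is called first, only, known or untested is meant among the compounds shown, and "the series" means these compounds.

Series notes, cytotoxicity set. For the measured compounds named here, compound 1 `O=c1[nH]c(=O)n([C@H]2C[C@H](O)[C@@H](CO)O2)cc1/C=C/I` is the one member with a measured number in an ADME assay on L1210/0 cells (Mus musculus) for cytotoxicity, with a stated time of 48 h; on this read-out lower numbers stand for stronger inhibition and higher numbers for weaker inhibition: compound 1 gives 63900 nM. Compound 2 `CCOc1ncnc2c1ncn2C[C@@H]1C[C@H](CO)c2ccccc21` is reported in this assay only as a limit, > 200000 nM. Compound 3 `CC1(C)C(CO)CC1Cn1cnc2c(N)nc(N)nc21` likewise stands at a limit in this assay, > 200000 nM. Going by the values given here, two of the three values therefore sit at the limit of > 200000 nM in this assay, at which 2 of the 3 values shown sit, so compound 1 is the only fixed point in the set and no step between measured compounds can be drawn.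

Compound 4 `O=c1[nH]c(=O)n([C@H]2C[C@H](O)[C@@H](CO)O2)cc1C#CCCO` has not yet been run in this assay. Against compound 1 the change is 4-hydroxybut-1-yn-1-yl in place of 2-iodoethenyl on an aromatic carbon. The group that enters brings a hydrogen-bond donor and a hydrogen-bond acceptor and a triple bond outside aromatic rings, where the group that leaves carried a double bond outside aromatic rings and an iodine. Among the compounds with values here, with no measured step in the set, the size of the move can only be estimated; a modest shift toward weaker inhibition, a little beyond the scatter, is expected: a 2.3-fold higher number from compound 1 to compound 4 (0.37 log units; beyond the scatter). The run on compound 4 may also return only a limit. Compound 4 is expected to give 150000 nM, in the range 40000 nM to 400000 nM.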

Compound 4, half-maximal inhibitory concentration: > 200000 nM
Compound 4: a limit, no number; the forecaster's own chance of this, stated with the estimate: 40%; middle value at least 1.3-fold (0.12 log units) from the limit.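

The series now has its first step, at this aromatic carbon of the shared core: an at least 3.1-fold higher number from compound 1 to compound 4 (0.49 log units; beyond the scatter). Compound 4 is only a limit, so this step fixes a direction and a lower bound on its size, and exchanging 2-iodoethenyl for 4-hydroxybut-1-yn-1-yl at this position moves the read-out toward weaker inhibition by a margin beyond the scatter. Compound 1 remains the only fixed number in the set, which leaves no second value to set this step against: the limit of > 200000 nM in this assay, at which 3 of the 4 values shown sit.

The exchange removes the iodine and the double bond and adds the triple bond and the hydroxyl together, so the compounds shown do not say which of these changes carries the step. A 2-bromoethenyl group, a but-1-yn-1-yl chain without the hydroxyl, or a chain ending in an amine would each remain to be read at this position.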